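Swapping Chloro for Methyl on the Way to Compound 4

The compounds below may be only part of what the source reports. "The series", "measured", "known", "first", "only" and "open" are said of these compounds alone.

Measured so far in a functional assay on KG-1 cells (Homo sapiens) for cytotoxicity, read by luminescence and CellTiter-Glo, with a stated time of 3 days; a lower number here means a stronger inhibitor, a higher number a weaker inhibitor:
Compound 1 `O=C(Nc1ccc(Br)c(Cl)c1)c1cc(F)ccc1O` gives 670 nM.
Compound 2 `N#Cc1ccc(NC(=O)c2cc(Cc3ccccc3)ccc2O)cc1` gives 1930 nM.
Compound 3 `N#Cc1ccc(NC(=O)c2ccc3cccnc3c2O)c(Cl)c1` gives 3670 nM.

Of these three numbers, compound 3 has the highest. Its distance to compound 1 lies beyond the usual scatter of repeated measurements, so compound 1 is the stronger inhibitor of that pair. Its distance to compound 2, on the other hand, falls within the scatter, so compound 2 and compound 3 cannot be told apart on this read-out.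

Compound 4 `Cc1cc(C#N)ccc1NC(=O)c1ccc2cccnc2c1O` has not yet been measured. It differs from compound 3 in a single place: methyl in place of chloro on an aromatic carbon. A chloro leaves and a methyl enters, each a single heavy atom with no ring and no hydrogen-bond donors or acceptors, on an aromatic carbon of a six-membered aromatic ring of carbon only, ortho to a large group and meta to a cyano group.

Among the compounds with values here, no measured pair shows this same swap, so the data give no size for it. The expectation is a step from compound 3 to compound 4 no larger than the scatter, in either direction, which is a 1.1-fold lower number from compound 3 to compound 4 (0.06 log units; within the scatter). Compound 4 is therefore estimated at 3200 nM in this assay, with a range from 1200 nM to 8500 nM.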

Compound 4, half-maximal inhibitory concentration: 3240 nM
Compound 4: the middle estimate sits 1.0-fold (0.01 log units) below what was measured; the measured number falls inside the stated range.
By their numbers in this assay, from the lowest: compound 1; then compounds 2, 4 and 3 (each within the scatter of the next).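

Within the data shown here, compound 3 and compound 4 are the first pair here that differ in a single place, so this is the first change whose size can be read on its own. In this assay the step is a 1.1-fold lower number from compound 3 to compound 4 (0.05 log units; within the scatter) and so lies within the scatter. Chloro and methyl therefore cannot be told apart on this read-out at this aromatic carbon, ortho to a large group and meta to a cyano group, and nothing shown here offers an explanation for that.

As far as these compounds go, this single swap says little about how much freedom the position allows, so it stays open whether an amine, a carboxylic acid or a longer chain on the same carbon would give a step beyond the scatter. From the compounds shown here alone, it also stays open whether methyl in place of chloro would give a similar result on the core of compound 1, which carries its own chloro in a different setting.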